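A few compounds are considered here, and "the series" means these few. Any claim that something is new, unique, unknown or untested is made for them only; others in the source may bear on it.

Compound 1 `COC(=O)[C@@]1(C)CCC=C2[C@@H]1CC[C@@H](C)[C@]2(C)Cc1c[nH]c2c(Br)cccc12` and compound 2 `COC(=O)[C@@]1(C)CCC=C2[C@@H]1CC[C@@H](C)[C@]2(C)Cc1c[nH]c2c(Cl)cccc12` share one core and differ in a single place: chloro in place of bromo on an aromatic carbon. In a functional assay on WiDr cells (Homo sapiens) for inhibition, read by sulforhodamine B assay, with a stated time of 48 h (on this read-out lower numbers stand for stronger inhibition of growth and higher numbers for weaker inhibition of growth), compound 1 gives 32000 nM, and compound 2 gives 31000 nM, so a 1.0-fold lower number from compound 1 to compound 2 (0.01 log units; within the scatter). Compound 3 `COC(=O)[C@@]1(C)CC[C@@H]2C3=C1CC[C@@H](C)[C@]3(C)Cc1c2[nH]c2c(Br)cccc12` is built on a different core; how the two cores differ is not broken down here. In this assay compound 3 gives 37000 nM. Compound 4 `COC(=O)[C@@]1(C)CC[C@@H]2C3=C1CC[C@@H](C)[C@]3(C)Cc1c2[nH]c2c(Cl)cccc12` is not yet measured and comes from compound 3 by the same kind of change, (chloro in place of bromo on an aromatic carbon), the ring system around the place now being part of a fused or bridged system of five rings rather than two. For compound 4 the expected step is a 1.0-fold lower number from compound 3 to compound 4 (0.01 log units; within the scatter), close to the measured one, because compound 1 to compound 2 showed a 1.0-fold lower number from compound 1 to compound 2 (0.01 log units; within the scatter). Compound 4 is therefore estimated at 36000 nM, likely between 18000 nM and 72000 nM.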

Compound 4, concentration for 50% growth inhibition: 21000 nM
Estimate against measurement, compound 4: 1.7-fold (0.23 log units) above; measured number inside the range.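

In this assay, chloro in place of bromo on the core of compound 3 gives a 1.8-fold lower number from compound 3 to compound 4 (0.25 log units; within the scatter). Set beside the same change on the core of compound 1, this step shows no difference larger than repeated measurements would produce: the same change on two cores in this assay, a 1.0-fold lower number (0.01 log units; within the scatter) from compound 1 to compound 2 and a 1.8-fold lower number (0.25 log units; within the scatter) from compound 3 to compound 4, 1.7-fold (0.23 log units) apart, within the scatter of two such steps. For the compounds shown here, on these two cores, then, the swap behaves alike as far as this assay can tell, but with only two pairs, each within the scatter, this does not show that the two steps are identical or that the same would hold on any other core.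

The compounds shown carry only bromo or chloro on this aromatic carbon, so the effect of fluoro, methoxy or an amine there remains open. Also open, as far as these compounds go, is what a carboxylic acid in place of the methyl ester would do.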